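A few compounds are considered here, and "the series" means these few. Any claim that something is new, unique, unknown or untested is made for them only; others in the source may bear on it.

For the measured compounds named here, compound 1 (`CCCC(=O)Oc1c(C(C)C)cc2c3c1OC(=O)[C@@]31CCCC(C)(C)[C@@H]1CC2`) gives 44400 nM in an ADME assay on MRC5 cells (Homo sapiens) for cytotoxicity, read by neutral red uptake, with a stated time of 24 h (on this read-out lower numbers stand for stronger inhibition and higher numbers for weaker inhibition), and is the only true number so far. Compound 2 (`CCCCCCCCCCCCCCCC(=O)Oc1c(C(C)C)cc2c3c1OC(=O)[C@@]31CCCC(C)(C)[C@@H]1CC2`) gives > 1000000 nM in this assay and that is a limit of the read-out, not a number. Compound 3 (`CCCCC/C=C/C/C=C/CCCCCCCC(=O)Oc1c(C(C)C)cc2c3c1OC(=O)[C@@]31CCCC(C)(C)[C@@H]1CC2`) departs from compound 2 by deca-1,4-dien-1-yl in place of octyl on a saturated chain carbon, seven bonds along the chain from a carbonyl carbon with the shared core unchanged: deca-1,4-dien-1-yl stands in place of octyl on a saturated chain carbon, seven bonds along the chain from a carbonyl carbon. Going by the values given here, only one measured step bears on this, namely an at least 22-fold higher number from compound 1 to compound 2 (1.35 log units; beyond the scatter) which is large and came from adding a long chain to a short one. Compound 3 keeps a long chain, so no step beyond the scatter is expected in this assay and another limit reading is plausible. The expected step is an at least 1.4-fold lower number from compound 2 to compound 3 (0.15 log units; that floor lies within the scatter) as an estimate only. Compound 3 is estimated at 700000 nM with an expected range from 200000 nM to 1000000 nM for now.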

Compound 3, half-maximal inhibitory concentration: 293000 nM
Estimate against measurement, compound 3: 2.4-fold (0.38 log units) above, within the range that was stated.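

In this assay, a long chain at this position does not by itself hold the read-out at the limit: deca-1,4-dien-1-yl in place of octyl, seven bonds along the chain from a carbonyl carbon, gives an at least 3.4-fold lower number from compound 2 to compound 3 (0.53 log units; beyond the scatter). The series now has a true number for a long chain, with compound 3 at 293000 nM, while compound 1 gives 44400 nM. The size of the step is only a floor because compound 2 stands at a limit of the read-out: the limit of > 1000000 nM in this assay, at which 1 of the 3 values shown sits.

The entering group differs from octyl in both its two double bonds and its length, and the compounds shown do not separate these two changes. Going by these compounds, how an amine or a carboxylic acid at the end of the chain would read in this assay also remains open.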